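This account rests on a few compounds, and the source may have more. Where it says the series, first, only, none or still open, it means among the compounds named here.

Compound 3 `CC(C)NC(=O)[C@H]1C[C@@H]1c1ccc(NCc2cccc(Oc3ccccc3)c2)cc1` gives the lowest number of the three measured in a functional assay on CHO cells for agonist activity at Free fatty acid receptor 1 (Homo sapiens) (on this read-out lower numbers stand for an effect already at smaller amounts and higher numbers for an effect only at larger amounts of compound), with 12.6 nM. Compound 1 `O=C(O)CCCc1ccc(NCc2cccc(Oc3ccccc3)c2)cc1` gives 1120 nM and compound 2 `CNC(=O)CCc1ccc(NCc2cccc(Oc3ccccc3)c2)cc1` gives 49 nM. The steps of a 23-fold lower number from compound 1 to compound 2 (1.36 log units; beyond the scatter) and a 3.9-fold lower number from compound 2 to compound 3 (0.59 log units; beyond the scatter) both alter the amide end of the molecule, and the step of an 89-fold lower number from compound 1 to compound 3 (1.95 log units; beyond the scatter) combines them. Compound 4 `O=C(NO)[C@H]1C[C@@H]1c1ccc(NCc2cccc(Oc3ccccc3)c2)cc1` is made from compound 3 by hydroxy in place of isopropyl on an amide-type nitrogen. Among the compounds with values here, no measured step swaps a group on the amide nitrogen itself; the only guide is that every amide in this set gives a low number, compound 2 being the closest analogue. Compound 4 is therefore expected to move only modestly, a 3.2-fold higher number from compound 3 to compound 4 (0.50 log units; beyond the scatter), with an estimated 40 nM, in a range from 10 nM to 160 nM.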

Compound 4, half-maximal effective concentration: 14.8 nM
Estimate against measurement, compound 4: 2.7-fold (0.43 log units) above; measured number inside the range.
By their numbers in this assay, from the lowest: compounds 3 and 4 (each within the scatter of the next); then compound 2; then compound 1.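

In this assay, hydroxy replaces isopropyl on the amide-type nitrogen with a 1.2-fold higher number from compound 3 to compound 4 (0.07 log units; within the scatter) and the read-out does not separate the two, although the group shrinks from three heavy atoms to one and gains a hydrogen-bond donor and acceptor. With the new group, a 3.3-fold lower number from compound 2 to compound 4 (0.52 log units; beyond the scatter) and a 76-fold lower number from compound 1 to compound 4 (1.88 log units; beyond the scatter) are both beyond the scatter, so the gains over the two chain compounds hold. No evidence bears on why this exchange leaves the number in place. On these data alone, whether a methoxy group, an amine or a longer chain on this nitrogen would be tolerated stays open, as does the effect of a bare hydrogen there.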